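This account rests on a few compounds, and the source may have more. Where it says the series, first, only, none or still open, it means among the compounds named here.

Of the compounds shown here, three built on the same core have been measured in a functional assay on MCF7 cells (Homo sapiens) for antiproliferative activity, read by MTT assay, with a stated time of 48 h; on this read-out lower numbers stand for stronger inhibition and higher numbers for weaker inhibition. Compound 1 `CCc1ccccc1-n1nncc1CN1C(=O)C2(C(C#N)=C(N)Oc3c(N)cc4nc5ccccc5nc4c32)c2ccccc21` gives 24600 nM. For compound 2 `CCOc1ccccc1-n1nncc1CN1C(=O)C2(C(C#N)=C(N)Oc3c(N)cc4nc5ccccc5nc4c32)c2ccccc21` the assay reports only a limit, > 50000 nM. For compound 3 `Cc1ccc(-n2nncc2CN2C(=O)C3(C(C#N)=C(N)Oc4c(N)cc5nc6ccccc6nc5c43)c3ccccc32)cc1C` the assay likewise reports only a limit, > 50000 nM. Compound 3 therefore stands at the upper edge of what this assay can resolve, and it shares that position with compound 2, as the limit of > 50000 nM in this assay, at which 2 of the 3 values shown sit, records. The step of an at least 2.0-fold higher number from compound 1 to compound 3 (0.30 log units; that floor lies within the scatter) came with 3,4-dimethylphenyl in place of 2-ethylphenyl on an aromatic nitrogen, while the step that the two limits leave unreadable from compound 2 to compound 3 cannot be read, since both of its values are limits.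

Compound 4 `Cc1cc(C)c(-n2nncc2CN2C(=O)C3(C(C#N)=C(N)Oc4c(N)cc5nc6ccccc6nc5c43)c3ccccc32)c(C)c1` has not yet been measured. It differs from compound 3 by 2,4,6-trimethylphenyl in place of 3,4-dimethylphenyl on an aromatic nitrogen. For the measured compounds named here, the only measured steps touching this position are those leading from compound 1 and compound 2 to compound 3, and neither shows a direction for a further change within the phenyl group. Compound 4 is therefore expected to remain close to compound 3, with an expected step of a number no higher from compound 3 to compound 4 (the limit leaves the size open) in this assay, and most likely once more only a limit. The estimate for compound 4 is 50000 nM, within a range from 15000 nM to 200000 nM.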

Compound 4, half-maximal inhibitory concentration: > 50000 nM
Compound 4 was reported as a limit (the forecaster's own chance of this, stated with the estimate: 65%); the middle value sits exactly at the limit.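

For the compounds shown here, replacing 3,4-dimethylphenyl with 2,4,6-trimethylphenyl on the aromatic nitrogen gives no readable number, so compound 4 is also reported only as a limit, and a third substituted phenyl group at this position now sits at the upper edge of this assay: the limit of > 50000 nM in this assay, at which 3 of the 4 values shown sit. Set against the only compound with a true number, the result is an at least 2.0-fold higher number from compound 1 to compound 4 (0.30 log units; that floor lies within the scatter), so this comparison, like the earlier ones from that compound, does not establish a change beyond the scatter. The steps linking compound 2, compound 3 and compound 4 join two limits and cannot be read, which leaves these three compounds without any order among them.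

From the compounds shown here alone, how much weaker than the limit compound 2, compound 3 and compound 4 may be remains unknown, and so does whether any of them truly differs from compound 1. Going by these compounds, it also remains open whether an amine or a carboxylic acid on this phenyl group, or a longer chain in place of the ethyl group of compound 1, would give a value that can be read as a number.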